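The compounds below may be only part of what the source reports. "The series", "measured", "known", "first", "only" and "open" are said of these compounds alone.

Compound 2, `C=C1/C(=C\C=C(/CCCC)c2cccc(CCCCCC(C)(C)O)c2)C[C@@H](O)C[C@@H]1O`, is the starting point. In an assay on MCF7 cells for agonist activity at vitamin D3 receptor (Homo sapiens), read by a luciferase reporter, with a stated time of 24 h (on this read-out higher numbers stand for an effect only at larger amounts of compound and lower numbers for an effect already at smaller amounts), compound 2 gives 9 nM, which is the higher of the two numbers recorded so far, although its gap to compound 1 stays within the scatter. Compound 1, `C=C1/C(=C\C=C(/CC)c2cccc(CCCCCC(C)(C)O)c2)C[C@@H](O)C[C@@H]1O`, is the only comparator: in this assay compound 1 gives 5.6 nM, and the step of a 1.6-fold higher number from compound 1 to compound 2 (0.21 log units; within the scatter) is therefore no real change.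

Compound 3, `C=C1/C(=C\C=C(/CCCCCCC)c2cccc(CCCCCC(C)(C)O)c2)C[C@@H](O)C[C@@H]1O`, has not yet been measured. It differs from compound 2 by propyl in place of hydrogen on a saturated chain carbon, four bonds along the chain from a double-bonded chain carbon. Among the compounds with values here, the one measured step that bears on this is the one from compound 1 to compound 2, where a chain on the same part of the core was lengthened and the number moved only within the scatter. On that basis a further lengthening of the chain is expected to leave the number in this assay close to that of compound 2, with at most a small rise: the expected step is a 1.3-fold higher number from compound 2 to compound 3 (0.12 log units; within the scatter). Compound 3 is therefore estimated to give 12 nM in this assay, within a range from 4.5 nM to 32 nM.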

Compound 3, half-maximal effective concentration: 29 nM
Compound 3: middle estimate off by 2.4-fold (0.38 log units), on the low side, and the stated range covers the measured number.
By their numbers in this assay, from the lowest: compounds 1 and 2 (each within the scatter of the next); then compound 3.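

In this assay the length of this chain now proves to matter, which compound 1 and compound 2 alone could not show: propyl in place of hydrogen on a saturated chain carbon, four bonds along the chain from a double-bonded chain carbon, gives a real though modest change (a 3.2-fold higher number from compound 2 to compound 3 (0.51 log units; beyond the scatter)), so an effect now needs a larger amount of compound. Taken from the shortest chain shown, the pentyl difference gives a larger change (a 5.2-fold higher number from compound 1 to compound 3 (0.71 log units; beyond the scatter)), so a lengthening that stayed within the scatter at first moves beyond it at the longest chain, and none of the three compounds goes against this. No measurement available here accounts for the change, so the data give its size and not its reason.

Within the data shown here, with only three chain lengths, it remains open whether a longer chain such as decyl would raise the number further or whether it would level off. Nor do these compounds tell how a branched chain such as isobutyl, a cyclohexyl ring or a chain ending in a hydroxyl or an amine would behave at this position.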